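Branching on the Aromatic Nitrogen: A Phenyl-Bearing Variant

This account rests on a few compounds, and the source may have more. Where it says the series, first, only, none or still open, it means among the compounds named here.

Among the measured compounds shown here, compound 2 `CCCCC(CC)n1ccc2cc(/C(C)=C/C(=O)Nc3ccccc3OCCCC(=O)O)ccc21` gives 7.1 nM in an assay on Prostate gland for inhibition of steroid 5-alpha-reductase (Rattus norvegicus) (on this read-out lower numbers stand for stronger inhibition and higher numbers for weaker inhibition), the lower of the two numbers measured so far. Compound 1 `CCCCCn1ccc2cc(/C(C)=C/C(=O)Nc3ccccc3OCCCC(=O)O)ccc21` gives 23 nM in this assay. The step of a 3.2-fold lower number from compound 1 to compound 2 (0.51 log units; beyond the scatter) added a branch on the saturated chain carbon bound to the aromatic nitrogen. Compound 3 `C/C(=C\C(=O)Nc1ccccc1OCCCC(=O)O)c1ccc2c(ccn2C(c2ccccc2)C(C)C)c1` keeps a branched group at that position but changes its nature: 2-methyl-1-phenylpropyl in place of 1-ethylpentyl on an aromatic nitrogen. For the measured compounds named here, only that single step bears on this change, and the entering group is of a different kind, so roughly no change beyond the scatter is expected, a step of a 1.1-fold higher number from compound 2 to compound 3 (0.05 log units; within the scatter). Compound 3 is therefore estimated at 8 nM, within a range from 2.5 nM to 25 nM.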

Compound 3, half-maximal inhibitory concentration: 25 nM
For compound 3 the middle estimate is 3.1-fold (0.49 log units) below the measured one; low and high end bracket the measured number.
By their numbers in this assay, from the lowest: compound 2; then compounds 1 and 3 (each within the scatter of the next).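

A branch on this nitrogen does not by itself give the lower number: replacing 1-ethylpentyl with the also branched 2-methyl-1-phenylpropyl brings a 3.5-fold higher number from compound 2 to compound 3 (0.55 log units; beyond the scatter) and removes the gain seen with 1-ethylpentyl. Set against the unbranched pentyl, the same group shows a 1.1-fold higher number from compound 1 to compound 3 (0.04 log units; within the scatter) and so sits level with it. No measurement here accounts for these differences. The entering group differs from 1-ethylpentyl in both its ring and its chain, so the compounds shown leave open which of these matters. A plain benzyl group or a 1-phenylpentyl group on this nitrogen remains to be seen.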